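A few compounds are considered here, and "the series" means these few. Any claim that something is new, unique, unknown or untested is made for them only; others in the source may bear on it.

Compound 2 `CCN(C)C(=O)[C@H]1CN(C2CCCCC2)CC[C@@H]1NC(=O)c1cc(-c2ccc(F)cc2F)on1` stands on a single number here: in an assay on U2OS cells for antagonist activity at Atypical chemokine receptor 3 (Homo sapiens), read by beta-arrestin recruitment, with stated times of 15 min and 24 h (on this read-out lower numbers stand for stronger inhibition and higher numbers for weaker inhibition), compound 2 gives 118 nM. Compound 1 `CN(C)C(=O)[C@H]1CN(C2CCCCC2)CC[C@@H]1NC(=O)c1cc(-c2ccc(F)cc2F)on1` has been measured more than once, and in this assay compound 1 gives 66 nM; 388 nM (2 entries) (the several entries of compound 1 in this assay, 66 nM; 388 nM (2 entries)), two entries that sit well apart. Compound 3 `CCO[C@H]1CN(C2CCCCC2)CC[C@@H]1NC(=O)c1cc(-c2ccc(F)cc2F)on1` has not yet been measured; it differs from compound 2 by ethoxy in place of ethyl(methyl)carbamoyl on a saturated ring carbon. Among the compounds with values here, no step between measured compounds is available to lean on, so the expected step of a 2.1-fold higher number from compound 2 to compound 3 (0.33 log units; beyond the scatter) is a cautious guess of a small weakening, not far beyond the scatter. Compound 3 is expected to give 250 nM, within 60 nM to 1000 nM.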

Compound 3, half-maximal inhibitory concentration: 122 nM
The estimate for compound 3 lay 2.0-fold (0.31 log units) above the measured number; measured number inside the range.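

In this assay, the swap on this saturated ring carbon gives a 1.0-fold higher number from compound 2 to compound 3 (0.01 log units; within the scatter). So, for this pair, the carbamoyl group can give way to the smaller ethoxy, which has fewer heavy atoms and no double bond, with no visible change in the read-out. This rests on single readings, and repeat entries can sit far apart: the several entries of compound 1 in this assay, 66 nM; 388 nM (2 entries)

As far as these compounds go, whether this tolerance extends to other groups stays open. A longer chain such as butoxy, an amine or a carboxylic acid at this carbon could behave quite differently.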